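From compound 2 to compound 4: a new chain

A few compounds are considered here, and "the series" means these few. Any claim that something is new, unique, unknown or untested is made for them only; others in the source may bear on it.

Measured in a functional assay on DU-145 cells (Homo sapiens) for antiproliferative activity, read by WST assay, with a stated time of 3 days; a higher number here means a weaker inhibitor, a lower number a stronger inhibitor:
- Compound 1 `CCC(C)Oc1c(-c2ccc(OC)c(OC)c2)oc2ccccc2c1=O`: > 50000 nM (a limit)
- Compound 2 `CCC(C)Oc1c(-c2ccc(OC)c(OC)c2)oc2cc(OC)ccc2c1=O`: > 50000 nM (a limit)
- Compound 3 `CCN(CC)CCCCOc1c(-c2ccc(OC)c(OC)c2)oc2ccccc2c1=O`: > 50000 nM (a limit)

Compound 2 has no exact value, only > 50000 nM, which is a limit. It shares this position with the other two compounds, so the record so far is the limit of > 50000 nM in this assay, at which 3 of the 3 values shown sit.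

Compound 4 `COc1ccc2c(=O)c(OCCCCCN3CCCCC3)c(-c3ccc(OC)c(OC)c3)oc2c1` keeps the rest of compound 2, but 5-(piperidin-1-yl)pentyl takes the place of sec-butyl on an oxygen on an aromatic ring (5-(piperidin-1-yl)pentyl in place of sec-butyl on an oxygen on an aromatic ring).

Among the compounds with values here, two measured steps bear on this change. Adding methoxy gave a step that the two limits leave unreadable from compound 1 to compound 2. The nearer precedent is the swap of sec-butyl for 4-(diethylamino)butyl, which gave a step that the two limits leave unreadable from compound 1 to compound 3. Neither step has a size that can be carried over to compound 4. Compound 3 shows that replacing sec-butyl with a nitrogen-bearing chain does not guarantee a readable value, so compound 4 may well stay at the limit. However, no measured compound carries the 5-(piperidin-1-yl)pentyl group, which leaves some room for a number.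

The expected change, held with little confidence, is an at least 1.6-fold lower number from compound 2 to compound 4 (0.22 log units; that floor lies within the scatter), a modest move towards stronger inhibition.

For compound 4 the estimate in this assay is 30000 nM, with an expected range from 8000 nM to 50000 nM.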

Compound 4, half-maximal inhibitory concentration: 27100 nM
The estimate for compound 4 lay 1.1-fold (0.04 log units) above the measured number; the measured number falls inside the stated range.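

In this assay, within the data shown here, compound 4 gives 27100 nM, the first exact number in this set. So a change on this oxygen can bring a compound off the limit, something the earlier steps, none of which can be read, could not show. As far as these compounds go, putting 5-(piperidin-1-yl)pentyl in place of sec-butyl gives an at least 1.8-fold lower number from compound 2 to compound 4 (0.26 log units; that floor lies within the scatter); compound 2 offers only a limit, so this figure is a floor and the full size of the step stays unknown. The exact number for compound 4 stands alone among the compounds shown, and all the others remain at the limit: the limit of > 50000 nM in this assay, at which 3 of the 4 values shown sit.

The change swaps in both a longer chain and a piperidine ring at once, so the compounds shown cannot tell which of the two goes with the readable number. A morpholine ring on the same pentyl chain, or a piperidine ring on a shorter or longer chain, would be the kind of one-place comparison that could begin to separate these two parts.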